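Carboxyphenyl position in the triazine anilines

The source may report more compounds than this note shows. Statements on the series, on what has been measured and on what is new or still open speak of the compounds shown alone.

Three compounds of the series have numbers in an assay on cells for activation of Cystic fibrosis transmembrane conductance regulator (Homo sapiens), read by fluorescence, with stated times of 10 min and 12 s; on this read-out higher numbers stand for an effect only at larger amounts of compound and lower numbers for an effect already at smaller amounts. Compound 1 `CCN(CC)c1nc(Nc2cccc(C(=O)O)c2)nc(OC(C(F)(F)F)C(F)(F)F)n1` gives 160 nM. Compound 2 `CCN(CC)c1nc(Nc2ccc3cn[nH]c3c2)nc(OC(C(F)(F)F)C(F)(F)F)n1` gives 900 nM, and the aryl exchange is a 5.6-fold higher number from compound 1 to compound 2 (0.75 log units; beyond the scatter). Compound 3 `CCN(CC)c1nc(Nc2cccc(C(=O)O)c2)nc(OCC(F)(F)C(F)F)n1` gives 500 nM, with the alkoxy exchange a 3.1-fold higher number from compound 1 to compound 3 (0.49 log units; beyond the scatter). Compound 3 thus stands second highest of the three, with compound 2 nearest and compound 1 furthest.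

Compound 4 `CCN(CC)c1nc(Nc2ccc(C(=O)O)cc2)nc(OCC(F)(F)C(F)F)n1` differs from compound 3 only at the aniline: 4-carboxyphenyl in place of 3-carboxyphenyl on a nitrogen on an aromatic ring. Among the compounds with values here, no measured step moves the carboxy group around the phenyl ring. Within the data shown here, the only step at this nitrogen, a 5.6-fold higher number from compound 1 to compound 2 (0.75 log units; beyond the scatter), exchanges the whole aryl group and is modest; the alkoxy step a 3.1-fold higher number from compound 1 to compound 3 (0.49 log units; beyond the scatter) is also modest and lies elsewhere. A position change within the same aryl group is therefore expected to be no larger than those, with direction uncertain; a small loss or no change beyond the scatter is the working expectation, a 1.4-fold higher number from compound 3 to compound 4 (0.15 log units; within the scatter). Compound 4 is estimated at 700 nM, expected to fall between 250 nM and 2000 nM.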

Compound 4, half-maximal effective concentration: 2500 nM
Beside the measured number, compound 4's estimate is 3.6-fold (0.55 log units) below it; the whole stated range lies below it.
By their numbers in this assay, from the lowest: compound 1; then compounds 3 and 2 (each within the scatter of the next); then compound 4.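

With the same atoms on both sides, moving the carboxy group from 3-carboxyphenyl to 4-carboxyphenyl on the aniline nitrogen in this assay gives a 5.0-fold higher number from compound 3 to compound 4 (0.70 log units; beyond the scatter), so the place of the carboxy group on the phenyl ring matters, not only which aryl group is present. Until now, the only change at this nitrogen was the whole-aryl exchange, a 5.6-fold higher number from compound 1 to compound 2 (0.75 log units; beyond the scatter), and this pair adds a clear preference for 3-carboxyphenyl, shown so far only with 2,2,3,3-tetrafluoropropyl on the oxygen. Nothing available explains this preference.

As far as these compounds go, whether the preference holds with 2,2,2-trifluoro-1-(trifluoromethyl)ethyl on the oxygen remains open. Also open, from the compounds shown here alone, is whether a primary amide or a methyl ester could replace the carboxylic acid of 3-carboxyphenyl.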